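Phenylsulfonyl on the ring nitrogen of compound 3

The source may hold more compounds than are shown below. What is called first, only, known or untested is meant among the compounds shown, and "the series" means these compounds.

Three compounds measured so far in a functional assay on QGY-7703 cells (Homo sapiens) for cytotoxicity, read by MTT assay, with a stated time of 24 h (a lower number here means a stronger inhibitor, a higher number a weaker inhibitor), are shown here.
- compound 1 `CN1C/C(=C\c2cccnc2)C(=O)/C(=C/c2ccccc2C(F)(F)F)C1` at 2910 nM
- compound 2 `O=C1/C(=C/c2cccnc2)CN(S(=O)(=O)c2ccccc2)C/C1=C\c1ccccc1F` at 4800 nM
- compound 3 `O=C1/C(=C/c2cccnc2)CNC/C1=C\c1ccccc1C(F)(F)F` at 3800 nM

Compound 3 at 3800 nM lies within the scatter of both other compounds, and the three values do not separate. The change to compound 4 `O=C1/C(=C/c2cccnc2)CN(S(=O)(=O)c2ccccc2)C/C1=C\c1ccccc1C(F)(F)F` is phenylsulfonyl in place of hydrogen on an amine nitrogen in a ring and puts phenylsulfonyl in place of hydrogen on an amine nitrogen in a ring. Going by the values given here, the one measured step on that nitrogen is a 1.3-fold higher number from compound 1 to compound 3 (0.12 log units; within the scatter) and stays within the scatter. Compound 2 carries phenylsulfonyl there and gives 4800 nM in the same range. In this assay no step beyond the scatter is therefore expected, and the estimated step of a 1.1-fold higher number from compound 3 to compound 4 (0.02 log units; within the scatter) stays within it. Compound 4 is expected at 4000 nM with an estimated range from 2000 nM to 8000 nM as the working figure.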

Compound 4, half-maximal inhibitory concentration: 6240 nM
For compound 4 the middle estimate is 1.6-fold (0.19 log units) below the measured one, within the range that was stated.
By their numbers in this assay, from the lowest: compounds 1, 3, 2 and 4 (each within the scatter of the next, the first and the last beyond it).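

In this assay phenylsulfonyl in place of hydrogen on the amine nitrogen in a ring gives a 1.6-fold higher number from compound 3 to compound 4 (0.22 log units; within the scatter) and trifluoromethyl in place of fluoro on an aromatic carbon gives a 1.3-fold higher number from compound 2 to compound 4 (0.11 log units; within the scatter) so neither single change separates from the scatter. Going by these compounds alone, only phenylsulfonyl in place of methyl on that nitrogen gives a 2.1-fold higher number from compound 1 to compound 4 (0.33 log units; beyond the scatter) and this modest step is the first beyond the scatter. No measurement here gives a reason for these steps.

Still open, on these data alone, is whether a benzyl group, an acetyl group or a carboxylic acid on a longer chain at that nitrogen would give a larger step.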